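The source may hold more compounds than are shown below. What is called first, only, known or untested is meant among the compounds shown, and "the series" means these compounds.

Compound 1 `COc1cc(OC)cc(-c2cccc(NC(=O)CCc3cccc4c3B(O)OC4)c2)c1`: 44 nM
Compound 2 `COc1cccc(-c2cccc(NC(=O)CCc3ccc4c(c3)B(O)OC4)c2)c1`: 62000 nM
Compound 3 `COc1cc(OC)cc(-c2cccc(NC(=O)CCc3ccc4c(c3)B(O)OC4)c2)c1`: 29000 nM

All three numbers come from a functional assay on SK-OV-3 cells (Homo sapiens) for antiproliferative activity, read by MTT assay, with a stated time of 72 h; on this read-out lower numbers stand for stronger inhibition and higher numbers for weaker inhibition. Compound 3 has the second highest of them, at 29000 nM, which places it close to compound 2 and very far from compound 1.

Compound 4 `CC(=O)c1ccc(-c2cccc(NC(=O)CCc3ccc4c(c3)B(O)OC4)c2)cc1` differs from compound 3 in one place: 4-acetylphenyl in place of 3,5-dimethoxyphenyl on an aromatic carbon.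

Two measured steps offer guidance, but they do not bear equally. The large one, a 660-fold higher number from compound 1 to compound 3 (2.82 log units; beyond the scatter), changes the group on the saturated chain, a part that stays the same in the new change, so it says little here. The other, a 2.1-fold lower number from compound 2 to compound 3 (0.33 log units; beyond the scatter), alters the same aromatic group that now gets replaced, and it is modest. For the measured compounds named here, no compound with an acetyl group has been measured, so the direction remains uncertain. Going by the values given here, with only that modest step as a guide, a small change in this assay is expected, possibly none beyond the scatter, with the number staying high. The estimated step is a 1.2-fold higher number from compound 3 to compound 4 (0.08 log units; within the scatter). The estimate for compound 4 is 35000 nM, with an expected range from 10000 nM to 100000 nM.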

Compound 4, half-maximal inhibitory concentration: > 100000 nM
Compound 4: a limit, no number; the forecaster's own chance of this, stated with the estimate: 15%; middle value at least 2.8-fold (0.45 log units) from the limit.
By their numbers in this assay, from the lowest: compound 1; then compound 3; then compound 2. At a limit, above all of these: compound 4.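

In this assay, compound 4 gives no number, only a limit of the assay: the limit of > 100000 nM in this assay, at which 1 of the 4 values shown sits. Until now this position had been probed only by the loss of one methoxy group, a modest change, whereas replacing 3,5-dimethoxyphenyl with 4-acetylphenyl gives an at least 3.4-fold higher number from compound 3 to compound 4 (0.53 log units; beyond the scatter), showing that a wider change to this aromatic group can move the number further upward even from an already high starting point. Replacing 3-methoxyphenyl with the same group gives an at least 1.6-fold higher number from compound 2 to compound 4 (0.20 log units; that floor lies within the scatter), so this comparison alone does not firmly separate the two compounds.

The compounds shown leave open whether the 4-acetylphenyl group would have a similar effect on the core of compound 1, which gives 44 nM and is the only compound here with a low number. They also cannot separate the effect of adding the acetyl group from that of losing the methoxy groups, and a comparison with an amine or a carboxylic acid in place of the acetyl group would show whether the outcome is specific to the acetyl group.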